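Replacing bromo with fluoro in compound 3

This account rests on a few compounds, and the source may have more. Where it says the series, first, only, none or still open, it means among the compounds named here.

Of the compounds shown here, three have so far been read in an ADME assay on L1210/0 cells (Mus musculus) for cytotoxicity, with a stated time of 48 h (on this read-out higher numbers stand for weaker inhibition and lower numbers for stronger inhibition), and they span a wide range. Compound 1 (`OC[C@@H]1C[C@H](Cn2cnc3c(NC4CC4)ncnc32)c2c(-c3ccccc3)nnc(-c3ccccc3)c21`) returns only a limit of the assay, > 200000 nM and not a number. Compound 2 (`Cc1ccc(C(=O)/C=C/c2cc(=O)[nH]c(=O)n2COCCO)cc1`) gives 27900 nM as its value. Compound 3 (`O=C1O/C(=C\Cn2cc(Br)c(=O)[nH]c2=O)C(OCc2ccccc2)=C1OCc1ccccc1`) gives 7500 nM and so holds the lowest number of the three, with a gap to compound 2 that lies beyond the usual scatter.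

Compound 4 (`O=C1O/C(=C\Cn2cc(F)c(=O)[nH]c2=O)C(OCc2ccccc2)=C1OCc1ccccc1`) keeps the rest of compound 3 and carries fluoro in place of bromo on an aromatic carbon. Among the compounds with values here, no measured pair in this small set shows such a swap, so the expectation rests on the structural change alone and remains wide. Stronger inhibition beyond the scatter is expected, with an estimated step of a 3.0-fold lower number from compound 3 to compound 4 (0.48 log units; beyond the scatter) in this assay as the likely size. For compound 4 the estimated value is 2500 nM within an expected range from 300 nM to 15000 nM in this reading.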

Compound 4, half-maximal inhibitory concentration: 5100 nM
Beside the measured number, compound 4's estimate is 2.0-fold (0.31 log units) below it; the range from low to high includes it.
By their numbers in this assay, from the lowest: compounds 4 and 3 (each within the scatter of the next); then compound 2. At a limit, above all of these: compound 1.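

In this assay, the aromatic carbon that carries the halogen gets its first direct reading, with a 1.5-fold lower number from compound 3 to compound 4 (0.17 log units; within the scatter) as the step for this swap. On this read-out, fluoro and bromo at this position cannot be told apart, although the two compounds are otherwise the same. So the change of one heavy atom for another, with the rest of compound 3 kept, leaves the value within the usual scatter. Nothing measured here speaks to what lies behind this result.

From the compounds shown here alone, whether a different kind of group at this position, such as a methyl, a trifluoromethyl or an amine, would shift the number beyond the scatter stays open. The compounds shown also leave open how a hydrogen there would read, since only two halogens have been compared at this position.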